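Hydrazine in Place of Chloride on the Chloromethyl Side Chain

The source may report more compounds than this note shows. Statements on the series, on what has been measured and on what is new or still open speak of the compounds shown alone.

Measured compounds:
Compound 1, `Nc1nn2c(O)cc(-c3ccccc3)nc2c1[N+](=O)[O-]`: in a functional assay on K562 cells (Homo sapiens) for inhibition (a lower number here means a stronger inhibitor of growth, a higher number a weaker inhibitor of growth), compound 1 gives a limit of > 50 ug/mL.
Compound 2, `Nc1nn2c(O)cc(-c3ccccc3F)nc2c1[N+](=O)[O-]`: in this assay compound 2 gives a limit of > 50 ug/mL.
Compound 3, `Nc1nn2c(O)cc(CCl)nc2c1[N+](=O)[O-]`: in this assay compound 3 gives a limit of > 50 ug/mL.

Compound 3 therefore stands at the limit of the assay, and so do the other two, as the limit of > 50 ug/mL in this assay, at which 3 of the 3 values shown sit, records. Among the measured compounds shown here, none of the measured steps can be read: a step that the two limits leave unreadable from compound 1 to compound 2, a step that the two limits leave unreadable from compound 1 to compound 3 and a step that the two limits leave unreadable from compound 2 to compound 3 all run between two limits. Compound 4, `NNCc1cc(O)n2nc(N)c([N+](=O)[O-])c2n1`, differs from compound 3 by aminoamino in place of chloro on a saturated chain carbon bound to an aromatic carbon. For the measured compounds named here, no measured step touches this change, and the three limits give no direction for it; the step that the limit leaves unreadable from compound 3 to compound 4 is thus expected to be small or unreadable, with no real guide to its sign. Compound 4 is estimated to give 60 ug/mL in this assay, within 25 ug/mL to 150 ug/mL, and most likely again only a limit.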

Compound 4, concentration for 50% growth inhibition: 26.5 ug/mL
Beside the measured number, compound 4's estimate is 2.3-fold (0.35 log units) above it, and the stated range covers the measured number.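

Among the compounds shown here, compound 4 is the only one of the four compounds to give a number rather than a limit in this assay, which shows that a change on the saturated chain carbon bound to an aromatic carbon can bring the series into readable range. Aminoamino in place of chloro gives an at least 1.8-fold lower number from compound 3 to compound 4 (0.27 log units; that floor lies within the scatter), and the wider replacements of the aromatic groups read as an at least 1.8-fold lower number from compound 2 to compound 4 (0.27 log units; that floor lies within the scatter) and an at least 1.8-fold lower number from compound 1 to compound 4 (0.27 log units; that floor lies within the scatter). These are floors rather than full sizes, and the steps among compounds 1, 2 and 3 cannot be read, as the remaining compounds all sit at one limit: the limit of > 50 ug/mL in this assay, at which 3 of the 4 values shown sit.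

On these data alone, the true size of the step from compound 3 to compound 4 stays open. Also open, as far as these compounds go, is how a simple amine, a hydroxyl or a longer chain ending in aminoamino would read at this place.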